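Swapping Methoxy for Benzylamino on the Carbonyl Carbon

The source may report more compounds than this note shows. Statements on the series, on what has been measured and on what is new or still open speak of the compounds shown alone.

Of the compounds shown here, two sharing one core have been tested in a functional assay on HEY cells (Homo sapiens) for cytotoxicity, read by MTT assay, with a stated time of 72 h; on this read-out lower numbers stand for stronger inhibition and higher numbers for weaker inhibition. In that test, compound 1 `CN(C)c1ccc(CNC(=O)c2nc(Br)c3cccnc3c2N[C@H]2CC[C@H](N)CC2)cc1` gives 5300 nM. Compound 2 `COC(=O)c1nc(Br)c2cccnc2c1N[C@H]1CC[C@H](N)CC1` is reported only as > 20000 nM, which is a limit of the assay and not a number.

Compound 3 `N[C@H]1CC[C@H](Nc2c(C(=O)NCc3ccccc3)nc(Br)c3cccnc23)CC1` has not yet been measured. It differs from compound 2 in a single place, with benzylamino in place of methoxy on a carbonyl carbon. Going by the values given here, no measured pair of compounds shows the size of such a change, so the expectation is a cautious one. It rests on compound 1, which at 5300 nM gives a measurable number, and it points toward stronger inhibition. The expected change is an at least 2.8-fold lower number from compound 2 to compound 3 (0.45 log units; beyond the scatter) in this assay. In this assay, the estimate for compound 3 is 7000 nM, with the result expected to fall between 2500 nM and 20000 nM.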

Compound 3, half-maximal inhibitory concentration: 8000 nM
Beside the measured number, compound 3's estimate is 1.1-fold (0.06 log units) below it; low and high end bracket the measured number.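

In this assay, benzylamino in place of methoxy on the carbonyl carbon gives an at least 2.5-fold lower number from compound 2 to compound 3 (0.39 log units; beyond the scatter), the first readable size for this change at this place. That step has no upper end, because compound 2 stands only as a limit of the assay and not as a number: the limit of > 20000 nM in this assay, at which 1 of the 3 values shown sits. Hydrogen in place of dimethylamino on an aromatic carbon gives a 1.5-fold higher number from compound 1 to compound 3 (0.18 log units; within the scatter), which lies within the scatter, so the plain benzylamino group already reaches the measurable range seen with compound 1, without the dimethylamino group.

The compounds shown leave open whether this step needs the aromatic ring of benzylamino or only the amide, which a methylamino group on the carbonyl carbon would separate. They also leave open how a carboxylic acid at this place, or a longer chain between the amide nitrogen and the ring, would read.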